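The source may hold more compounds than are shown below. What is called first, only, known or untested is meant among the compounds shown, and "the series" means these compounds.

Compound 1 `COC(=O)c1cc(-c2cccc(NC(=O)c3ccc(/C=C/C(=O)c4ccc(OC)cc4OC)cc3)c2)on1` and compound 2 `CCCOc1ccc(C(=O)/C=C/c2ccc(C(=O)O)cc2)cc1` were both examined in an ADME assay on Vero cells (Chlorocebus sabaeus) for cytotoxicity, read by MTT assay, with a stated time of 72 h; on this read-out lower numbers stand for higher toxicity in this test and higher numbers for lower toxicity in this test. In this assay compound 1 gives > 50 ug/mL, which is a limit of the assay and not a measured number. Compound 2 gives < 10 ug/mL in this assay, again a limit rather than a number. Compound 1 therefore stands at the limit of > 50 ug/mL in this assay, at which 1 of the 2 values shown sits, whereas the other value shown sits at the limit of < 10 ug/mL in this assay, at which 1 of the 2 values shown sits. Going by the values given here, no step between measured compounds is available. Compound 1 and compound 2 differ in more than one place. Compound 3 `COC(=O)c1cc(-c2cccc(NC(=O)c3ccc(/C=C/C(=O)c4ccccc4Cl)cc3)c2)on1` is still to be measured in this assay. It differs from compound 1 by 2-chlorophenyl in place of 2,4-dimethoxyphenyl on a carbonyl carbon. Because compound 1 sits at the limit of > 50 ug/mL in this assay, at which 1 of the 2 values shown sits, the step from compound 1 to compound 3 is expected to be an at least 1.1-fold lower number from compound 1 to compound 3 (0.04 log units; that floor lies within the scatter), with no change beyond the scatter. Compound 3 is accordingly estimated to give 45 ug/mL in this assay, within 18 ug/mL to 110 ug/mL.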

Compound 3, half-maximal cytotoxic concentration: > 25 ug/mL
Compound 3: only a limit was reported; the forecaster's own chance of this, stated with the estimate: 55%; the middle value lies beyond the limit too.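

In this assay, compound 1 and compound 3 are both reported only as limits, and no step can be read between them. The compounds shown leave open whether 2-chlorophenyl in place of 2,4-dimethoxyphenyl on a carbonyl carbon changes the half-maximal cytotoxic concentration at all.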